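The compounds below may be only part of what the source reports. "The series", "measured", "known", "first", "only" and "open" are said of these compounds alone.

Working notes on the series. Three compounds of the shared core have numbers in a functional assay on THP-1 cells (Homo sapiens) for cytotoxicity, read by MTT assay, with a stated time of 24 h; a higher number here means a weaker inhibitor, a lower number a stronger inhibitor. Compound 1 `COc1cc2nc(Cl)nc(NS(=O)(=O)c3ccccc3)c2cc1OC` gives 8.17 ug/mL. Compound 2 `COc1cc2nc(N3CCCC3)nc(NS(=O)(=O)c3ccc(C)cc3)c2cc1OC` gives 7.06 ug/mL, the lowest of the three numbers, though compound 1 sits within the scatter of it. Among the measured compounds shown here, compound 3 `COc1cc2nc(N3CCCC3)nc(NS(=O)(=O)c3cccc(C(F)(F)F)c3)c2cc1OC` gives 15.9 ug/mL; the one single-point step measured so far, a 2.3-fold higher number from compound 2 to compound 3 (0.35 log units; beyond the scatter), concerns the group on the sulfonyl sulfur and does not touch the position changed here.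

Compound 4 `COc1cc2nc(Cl)nc(NS(=O)(=O)c3ccc(C)cc3)c2cc1OC` differs from compound 2 as follows: chloro in place of pyrrolidin-1-yl on an aromatic carbon. For the measured compounds named here, no measured step covers this change on its own. Compound 1 also carries chloro at this position, but it differs from compound 2 in the group on the sulfonyl sulfur as well, so only its value informs, and the values of compound 1 and compound 2 lie within the scatter of one another. The step expected is therefore none beyond the scatter, a 1.1-fold higher number from compound 2 to compound 4 (0.05 log units; within the scatter). For compound 4 the estimate in this assay is 8 ug/mL, with a range from 4 ug/mL to 16 ug/mL.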

Compound 4, half-maximal inhibitory concentration: 33.5 ug/mL
For compound 4 the middle estimate is 4.2-fold (0.62 log units) below the measured one; the measured number lies above the stated range.
By their numbers in this assay, from the lowest: compounds 2, 1 and 3 (each within the scatter of the next, the first and the last beyond it); then compound 4.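

With the 4-methylphenyl group on the sulfonyl sulfur held fixed, the position between the two ring nitrogen atoms now has its own reading in this assay: chloro in place of pyrrolidin-1-yl gives a 4.7-fold higher number from compound 2 to compound 4 (0.68 log units; beyond the scatter) and so is not a silent change, which the closeness of compound 1 and compound 2 had concealed. With chloro held fixed, methyl in place of hydrogen on an aromatic carbon gives a 4.1-fold higher number from compound 1 to compound 4 (0.61 log units; beyond the scatter) as well. Both steps lie beyond the scatter, and both end at the higher number of compound 4. Nothing available explains either step.

From the compounds shown here alone, whether a morpholine or an open-chain amine such as dimethylamino at this position would behave like pyrrolidin-1-yl remains open. Also open, going by these compounds, is whether the chloro step holds with 3-(trifluoromethyl)phenyl on the sulfonyl sulfur.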